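The source may hold more compounds than are shown below. What is called first, only, known or untested is meant among the compounds shown, and "the series" means these compounds.

Measured compounds:
- Compound 1, `Nc1nc(Cl)nc(Nc2ccc(N3CCOCC3=O)cc2)n1`: in a functional assay on the whole organism (strain Swiss) for inhibition, with Mus musculus as the target, with a stated time of 30 min, at a dose of 5 mg/kg by the intraperitoneal route (a lower number here means a weaker effect, a higher number a stronger effect of the compound at the dose given), compound 1 gives 67%.
- Compound 2, `O=C1COCCN1c1ccc(Nc2nc(Cl)nc(N3CCCC3)n2)cc1`: in this assay compound 2 gives 87%.
- Compound 3, `O=C1COCCN1c1ccc(Nc2nc(Cl)nc(NC3CCCCC3)n2)cc1`: in this assay compound 3 gives 56%.

Compound 3 stands lowest of the three numbers in this assay; the nearest is compound 1, and the step of a number 11 percentage points lower from compound 1 to compound 3 (beyond the scatter) is modest, while a number 31 percentage points lower from compound 2 to compound 3 (beyond the scatter) is large. The unmeasured compound 4, `O=C1COCCN1c1ccc(Nc2nc(Cl)nc(Nc3ccc(Cl)cc3)n2)cc1`, differs from compound 3 in one place: 4-chlorophenyl in place of cyclohexyl on a nitrogen on an aromatic ring. Among the measured compounds shown here, none of the measured steps exchanges cyclohexyl for an aromatic group on this nitrogen, so none bears on the change directly. For the measured compounds named here, the two steps that touch this nitrogen, a number 11 percentage points lower from compound 1 to compound 3 (beyond the scatter) and a number 31 percentage points lower from compound 2 to compound 3 (beyond the scatter), show only that changing the group here moves the number by a modest to large amount in either direction. The expected step of a number 4 percentage points higher from compound 3 to compound 4 (within the scatter) is therefore set near zero, with a wide range. Compound 4 is estimated to give 60% in this assay, between 35% and 85%.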

Compound 4, a percentage reported as inhibition, in the whole organism at one dose (the size of the read-out at that dose, not a potency): 79%
Compound 4: middle estimate off by 19 percentage points, on the low side; low and high end bracket the measured number.
By their numbers in this assay, from the lowest: compound 3; then compound 1; then compounds 4 and 2 (each within the scatter of the next).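

In this assay the nitrogen on an aromatic ring proves able to carry a six-membered ring without the number falling: cyclohexyl had stood below the plain hydrogen, while 4-chlorophenyl gives a rise over both cyclohexyl (a number 23 percentage points higher from compound 3 to compound 4 (beyond the scatter)) and hydrogen (a number 12 percentage points higher from compound 1 to compound 4 (beyond the scatter)). Set against the pyrrolidin-1-yl of compound 2, (4-chlorophenyl)amino cannot be told apart (a number 8 percentage points lower from compound 2 to compound 4 (within the scatter)), so among these compounds the low number belongs to cyclohexylamino alone. Nothing available explains why these groups differ in this way.

On these data alone, whether a plain phenyl or a 4-methoxyphenyl on this nitrogen would match 4-chlorophenyl stays open, and with it the share of the chlorine in the result. Also open, as far as these compounds go, is whether a piperidin-1-yl or a morpholin-4-yl would keep the number seen with pyrrolidin-1-yl.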